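Removing the Methylamino Group from the Shared Core

The source may report more compounds than this note shows. Statements on the series, on what has been measured and on what is new or still open speak of the compounds shown alone.

Compound 2 `CNc1nc2c(Cl)c(Cl)ccc2n1COCCO` carries a methylamino group on its shared core. In a functional assay on KB cells (Homo sapiens) for inhibition (a lower number here means a stronger inhibitor, a higher number a weaker inhibitor), compound 2 gives > 100000 nM, which is a limit of the assay rather than a number. Compound 1 `Nc1nc2c(Cl)c(Cl)ccc2n1COCCO` differs from it only by hydrogen in place of methyl on a nitrogen on an aromatic ring. In this assay compound 1 gives > 100000 nM, again a limit and not a number. The step that the two limits leave unreadable from compound 1 to compound 2 therefore cannot be sized, since (the limit of > 100000 nM in this assay, at which 2 of the 2 values shown sit). Compound 3 `OCCOCn1cnc2c(Cl)c(Cl)ccc21` takes the change further: hydrogen in place of methylamino on an aromatic carbon. Among the compounds with values here, no measured step bears on this change, and the only recorded step is unreadable. Because (the limit of > 100000 nM in this assay, at which 2 of the 2 values shown sit), compound 3 is expected to stay at that limit, with the step of a number no higher from compound 2 to compound 3 (the limit leaves the size open) expected to show nothing beyond the scatter. Compound 3 is thus estimated at 100000 nM, within a range from 20000 nM to 300000 nM, most likely reported only as a limit.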

Compound 3, half-maximal inhibitory concentration: > 100000 nM
Compound 3: a limit, no number; the forecaster's own chance of this, stated with the estimate: 85%; the middle value sits exactly at the limit.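

In this assay compound 3 gives > 100000 nM and this is a limit, not a number. Within the data shown here, no step among compound 1, compound 2 and compound 3 can be read: the limit of > 100000 nM in this assay, at which 3 of the 3 values shown sit. The compounds shown leave open how far each lies from that limit.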